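The source may report more compounds than this note shows. Statements on the series, on what has been measured and on what is new or still open speak of the compounds shown alone.

In a functional assay on HepG2 cells (Homo sapiens) for antiproliferative activity, read by MTT assay, with a stated time of 48 h (on this read-out higher numbers stand for weaker inhibition and lower numbers for stronger inhibition), compound 1 `CCN(CC)CCNC(=O)c1ccc(C(CC)(CC)c2ccc(OCCC(O)(CC)CC)c(C)c2)n1CC` gives 230 nM as its value. Compound 2 `CCn1c(C(=O)NCC#N)ccc1C(CC)(CC)c1ccc(OCCC(O)(CC)CC)c(C)c1` reaches only the assay limit of > 50000 nM in this assay, so its place is fixed by the limit of > 50000 nM in this assay, at which 1 of the 3 values shown sits, rather than by a number. Compound 3 `CCOC(=O)CN(C)C(=O)c1ccc(C(CC)(CC)c2ccc(OCCC(O)(CC)CC)c(C)c2)n1CC` gives 25300 nM in this assay. The steps of an at least 210-fold higher number from compound 1 to compound 2 (2.33 log units; beyond the scatter) and a 110-fold higher number from compound 1 to compound 3 (2.04 log units; beyond the scatter) both lose activity sharply, whereas an at least 1.9-fold lower number from compound 2 to compound 3 (0.29 log units; that floor lies within the scatter) stays within the scatter between two weak amides. Compound 4 `CCn1c(C(=O)NC(C)C(=O)O)ccc1C(CC)(CC)c1ccc(OCCC(O)(CC)CC)c(C)c1` is next for this assay. 1-carboxyethyl in place of cyanomethyl on an amide-type nitrogen Both earlier steps away from compound 1 gave large losses and the two analogues without its amine sit together at the weak end, so the step that the limit leaves unreadable from compound 2 to compound 4 is expected to stay within the scatter. Compound 4 is therefore estimated at 60000 nM with a range from 20000 nM to 200000 nM and a fair chance of another limit.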

Compound 4, half-maximal inhibitory concentration: 1740 nM
The estimate for compound 4 lay 34-fold (1.54 log units) above the measured number; the measured number lies below the stated range.
By their numbers in this assay, from the lowest: compound 1; then compound 4; then compound 3. At a limit, above all of these: compound 2.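

On the amide-type nitrogen, 1-carboxyethyl separates clearly from the weak amides in this assay: an at least 28-fold lower number from compound 2 to compound 4 (1.45 log units; beyond the scatter) and a 15-fold lower number from compound 3 to compound 4 (1.16 log units; beyond the scatter), so losing the 2-(diethylamino)ethyl group does not by itself place an analogue at the weak end. Even so, there is a 7.6-fold higher number from compound 1 to compound 4 (0.88 log units; beyond the scatter), which leaves compound 1 ahead of compound 4. Compound 2 stands at a limit, not at a number: the limit of > 50000 nM in this assay, at which 1 of the 4 values shown sits.

From the compounds shown here alone, it remains open whether the gain follows the carboxylic acid or its methyl branch; carboxymethyl or the ethyl ester of 1-carboxyethyl on this nitrogen would separate the two. Going by these compounds, how a longer chain ending in a carboxylic acid compares with the diethylamino chain also remains open.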